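The compounds below may be only part of what the source reports. "The series", "measured", "known", "first", "only" and "open" are said of these compounds alone.

Measured in a functional assay with Homo sapiens as the target; on this read-out lower numbers stand for stronger inhibition and higher numbers for weaker inhibition:
- compound 1 `CC(C)[C@H](NC(=O)COc1cccc2ccccc12)C(=O)N[C@@H](CC(=O)O)C(=O)COc1cccc2ccccc12`: 19000 nM
- compound 2 `CC(C)[C@H](NC(=O)COc1cccc2ccccc12)C(=O)N[C@@H](CC(=O)O)C(=O)COc1ccc2ccccc2c1`: 15900 nM
- compound 3 `CC(C)[C@H](NC(=O)COc1cccc2ccccc12)C(=O)N[C@@H](CC(=O)O)C(=O)COc1ccc(-c2ccccc2)cc1`: 38700 nM

Compound 2 stands at the low end of these numbers, but not alone: the data show a 1.2-fold lower number from compound 1 to compound 2 (0.08 log units; within the scatter). In the other direction, the data show a 2.4-fold higher number from compound 2 to compound 3 (0.39 log units; beyond the scatter).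

Compound 4 `CC(C)[C@H](NC(=O)COc1cccc2ccccc12)C(=O)N[C@@H](CC(=O)O)C(=O)COc1ccccc1C(F)(F)F` keeps the shared core. The change is 2-(trifluoromethyl)phenyl in place of naphthalen-2-yl on an oxygen on a saturated carbon.

All three measured steps bear on this change, since each swaps the group at that same place. The third is a 2.0-fold higher number from compound 1 to compound 3 (0.31 log units; beyond the scatter). Within the data shown here, none of them goes beyond a modest size, and no measured compound carries a trifluoromethyl group, so there is no direct precedent. Among the measured compounds shown here, the swap to compound 3, at 38700 nM, is the only one that moved the number beyond the scatter, and it moved it upward. In this assay, a small upward shift is therefore expected at most, and it may well stay within the scatter. The expected change is a 1.5-fold higher number from compound 2 to compound 4 (0.18 log units; within the scatter). Compound 4 is estimated at 24000 nM, with an expected range of 11000 nM to 50000 nM.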

Compound 4, half-maximal inhibitory concentration: 17300 nM
Beside the measured number, compound 4's estimate is 1.4-fold (0.14 log units) above it; the measured number falls inside the stated range.
By their numbers in this assay, from the lowest: compounds 2, 4 and 1 (each within the scatter of the next); then compound 3.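

In this assay, 2-(trifluoromethyl)phenyl, with one six-membered aromatic ring, stays level with both groups that have two such rings, as a 1.1-fold higher number from compound 2 to compound 4 (0.04 log units; within the scatter) and a 1.1-fold lower number from compound 1 to compound 4 (0.04 log units; within the scatter) show. At this place, on an oxygen on a saturated carbon, the compounds shown therefore do not require the naphthalene groups to keep the number at this level, while the earlier compounds offered no one-ring group to test this. Compound 3 is the one that stands apart, with a 2.2-fold lower number from compound 3 to compound 4 (0.35 log units; beyond the scatter), so the step beyond the scatter seen earlier for 4-phenylphenyl is not shared by this one-ring group; no evidence is available to explain any of these results.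

From the compounds shown here alone, it remains open whether the trifluoromethyl group contributes at all, since an unsubstituted phenyl group or a 2-methylphenyl group would be needed to separate it from the ring alone. Going by these compounds, it is equally open whether an amine, a carboxylic acid or a longer chain at this place would produce a step larger than the modest ones seen so far, in either direction.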